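Switching the amine linker to a carbamoyl in a labdane-type series

The source may report more compounds than this note shows. Statements on the series, on what has been measured and on what is new or still open speak of the compounds shown alone.

Compound 1 `C=C1CC[C@@H]2[C@](C)(CNCc3ccc(C)cc3)[C@H](O)CC[C@@]2(C)[C@@H]1/C=C/C1=CCOC1=O`: 740 nM
Compound 2 `C=C1CC[C@@H]2[C@](C)(CNCc3cccc(OC)c3)[C@H](O)CC[C@@]2(C)[C@@H]1/C=C/C1=CCOC1=O`: 780 nM
Compound 3 `C=C1CC[C@@H]2[C@](C)(CNCc3ccncc3)[C@H](O)CC[C@@]2(C)[C@@H]1/C=C/C1=CCOC1=O`: 2030 nM

In a functional assay on BMMC cells (Mus musculus, strain C57BL/6) for inhibition, with stated times of 5 days and 48 h (a lower number here means a stronger inhibitor, a higher number a weaker inhibitor), compound 3 gives the highest of the three numbers. The steps toward it were a 2.7-fold higher number from compound 1 to compound 3 (0.44 log units; beyond the scatter) and a 2.6-fold higher number from compound 2 to compound 3 (0.42 log units; beyond the scatter), while a 1.1-fold higher number from compound 1 to compound 2 (0.02 log units; within the scatter) shows the two carbon-only aryl groups as equivalent. Compound 4 `C=C1CC[C@H]2[C@@](C)(CC[C@@H](O)[C@@]2(C)C(=O)NCc2ccc(Br)cc2)[C@@H]1/C=C/C1=CCOC1=O` is reached by (4-bromobenzyl)carbamoyl in place of (((pyridin-4-yl)methyl)amino)methyl on a saturated ring carbon. The measured steps bear on this only insofar as the pyridin-4-yl leaves in favour of a six-membered aromatic ring of carbon only, which in compounds 1 and 2 went with lower numbers; nothing measured covers the change from an amine to a carbamoyl, so the range is kept wide. The estimate for compound 4 is 900 nM (range 300 nM to 3000 nM), a step of a 2.3-fold lower number from compound 3 to compound 4 (0.35 log units; beyond the scatter) expected.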

Compound 4, half-maximal inhibitory concentration: 3450 nM
Beside the measured number, compound 4's estimate is 3.8-fold (0.58 log units) below it; measured number outside the range, above it.
By their numbers in this assay, from the lowest: compounds 1 and 2 (each within the scatter of the next); then compounds 3 and 4 (each within the scatter of the next).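

In this assay, the change at this saturated ring carbon to (4-bromobenzyl)carbamoyl gives a 4.7-fold higher number from compound 1 to compound 4 (0.67 log units; beyond the scatter) and a 4.4-fold higher number from compound 2 to compound 4 (0.65 log units; beyond the scatter) when set against the two amines with carbon-only aromatic rings. Against the pyridin-4-yl amine it gives a 1.7-fold higher number from compound 3 to compound 4 (0.23 log units; within the scatter), so a six-membered aromatic ring of carbon only does not by itself bring the lower numbers seen with compound 1 and compound 2. No evidence bears on why this is so.

In this assay the compounds shown leave open whether a carbamoyl carrying 4-methylbenzyl or 3-methoxybenzyl would match its amine counterpart, which would separate the linker from the bromine. Going by these compounds, how a carboxylic acid or a longer chain would read at this ring carbon also stays open.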